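Replacing a Phenyl with a Chain on the Ring Nitrogen

This account rests on a few compounds, and the source may have more. Where it says the series, first, only, none or still open, it means among the compounds named here.

Three compounds share the core of compound 1 `CN(C)C(=S)SC(=S)N1CCCCC1`. In an ADME assay on HeLa cells (Homo sapiens) for cytotoxicity, read by MTT assay, with a stated time of 24 h (on this read-out higher numbers stand for weaker inhibition and lower numbers for stronger inhibition), compound 1 gives only a limit, > 5000000 nM. Compound 2 `CN(C)C(=S)SC(=S)N1CCN(c2ccccc2)CC1` gives 1610000 nM in this assay, the lower of the two numbers. Among the measured compounds shown here, compound 3 `COc1ccccc1N1CCN(C(=S)SC(=S)N(C)C)CC1` gives 4330000 nM, and the step of a 2.7-fold higher number from compound 2 to compound 3 (0.43 log units; beyond the scatter) is the only one-place step measured. Compound 4 `CCCCNC(=S)N1CCN(C(=S)SC(=S)N(C)C)CC1` is not yet measured; it differs from compound 2 by a group of 7 heavy atoms (5 carbon, 1 nitrogen, 1 sulfur; no ring) in place of a group of 6 heavy atoms (6 carbon; one six-membered aromatic ring of carbon only), on an amine nitrogen in a ring. For the measured compounds named here, no measured step exchanges an aromatic ring for a chain, so the modest step from compound 2 to compound 3 is the only guide, and it concerns a different change. A step of similar or smaller size in either direction is expected, a 1.6-fold higher number from compound 2 to compound 4 (0.19 log units; within the scatter). Compound 4 is therefore estimated at 2500000 nM, within 800000 nM to 8000000 nM.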

Compound 4, half-maximal inhibitory concentration: 2840000 nM
Compound 4: middle estimate off by 1.1-fold (0.06 log units), on the low side; low and high end bracket the measured number.
By their numbers in this assay, from the lowest: compounds 2, 4 and 3 (each within the scatter of the next, the first and the last beyond it). At a limit, above all of these: compound 1.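

Replacing the phenyl on the amine nitrogen in the ring with a chain that has no ring gives a 1.8-fold higher number from compound 2 to compound 4 (0.25 log units; within the scatter). The earlier step changed only a group on the phenyl, whereas this one removes the aromatic ring itself, and in this assay the number stays within the scatter. Compound 1 remains a limit rather than a number, so it cannot be placed in this order: the limit of > 5000000 nM in this assay, at which 1 of the 4 values shown sits.

The compounds shown do not separate the effect of losing the ring from that of adding the chain's nitrogen and sulfur. From the compounds shown here alone, whether a plain alkyl chain, a longer chain or a carboxylic acid would be tolerated at this nitrogen remains open.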